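Swapping a furfuryl urea for a phenyl urea on a nitropyrrole

The source may report more compounds than this note shows. Statements on the series, on what has been measured and on what is new or still open speak of the compounds shown alone.

Two compounds sharing a nitro-substituted pyrrole carbohydrazide core have been examined for cytotoxicity. Compound 1 `O=C(NCc1ccco1)NNC(=O)c1cc([N+](=O)[O-])c[nH]1` carries a (furan-2-yl)methyl urea on the hydrazide. In an ADME assay on Vero cells (Chlorocebus sabaeus) for cytotoxicity, read by MTT assay, with a stated time of 72 h (on this read-out higher numbers stand for weaker inhibition and lower numbers for stronger inhibition), compound 1 gives 443000 nM, the higher of the two numbers recorded, which places it as the weaker inhibitor of cell viability of the pair. Compound 2 `O=C(NNC(=S)NC1CCCCC1)c1cc([N+](=O)[O-])c[nH]1`, a cyclohexyl thiourea analogue on the same core, gives 204000 nM in this assay, a lower number that sits beyond the usual scatter of the measurement.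

Compound 3 `O=C(NNC(=O)c1cc([N+](=O)[O-])c[nH]1)Nc1ccccc1` is not yet measured. It differs from compound 1 in one place: phenyl in place of (furan-2-yl)methyl on an amide-type nitrogen. Going by the values given here, no measured pair shows this change on this core, so its effect can only be guessed. Both measured compounds sit in the weakly cytotoxic range, and a phenyl in place of (furan-2-yl)methyl on the amide-type nitrogen is not expected to move the number beyond the scatter, so the step of a 1.3-fold lower number from compound 1 to compound 3 (0.10 log units; within the scatter) is estimated to be small. Compound 3 is expected to give about 350000 nM, within a range from 150000 nM to 800000 nM.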

Compound 3, half-maximal inhibitory concentration: 357000 nM
The estimate for compound 3 lay 1.0-fold (0.01 log units) below the measured number; low and high end bracket the measured number.
By their numbers in this assay, from the lowest: compounds 2, 3 and 1 (each within the scatter of the next, the first and the last beyond it).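

Going by these compounds alone, the measured step is a 1.2-fold lower number from compound 1 to compound 3 (0.09 log units; within the scatter) in this assay and gives the first reading of a single change at this place, an amide-type nitrogen whose other neighbour is a carbonyl carbon. Phenyl in place of (furan-2-yl)methyl exchanges a five-membered aromatic ring with one hetero atom for a six-membered aromatic ring of carbon only, and loses one hydrogen-bond acceptor, yet this exchange does not separate compound 1 from compound 3 on this read-out. No measurement at hand bears on why the number stays within the scatter across this change.

The compounds shown cover only these two groups on this nitrogen on the shared core, so it remains open whether a group of another kind, such as a carboxylic acid, an amine or a longer alkyl chain, would shift the number beyond the scatter. Within the data shown here, also open is whether phenyl in place of (furan-2-yl)methyl would behave in the same way on a thiourea such as the one in compound 2.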